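Methyl on the Core: Expected Effect on Solubility

This account rests on a few compounds, and the source may have more. Where it says the series, first, only, none or still open, it means among the compounds named here.

Compound 1 `Cc1c(COCCCCO)[nH]c2ccccc2c1=O` sits at >= 100000 nM in a physicochemical assay for solubility, at pH 6.8 (on this read-out lower numbers stand for lower solubility and higher numbers for higher solubility), which is a limit of the assay rather than a number (the limit of >= 100000 nM in this assay, at which 1 of the 3 values shown sits). Compound 2 `Cc1c(COc2cccc(OCC3CCOCC3)c2)[nH]c2ccc(Cl)cc2c1=O` is reported at < 1000 nM, again a limit of the assay (the limit of < 1000 nM in this assay, at which 1 of the 3 values shown sits). Among the measured compounds shown here, compound 3 `O=c1cc(COc2cccc(OCC3CCOCC3)c2)[nH]c2ccccc12` gives 4000 nM, the only value among the three that is a number. Compound 4 `Cc1c(COc2cccc(OCC3CCOCC3)c2)[nH]c2ccccc2c1=O` remains to be measured in this assay; it differs from compound 3 by methyl in place of hydrogen on an aromatic carbon, on an aromatic carbon of a six-membered aromatic ring with 1 nitrogen, ortho to a large group. For the measured compounds named here, no step between measured compounds is available, so the direction rests on the change alone. The solubility of compound 4 is expected to be somewhat lower, with the step of a 2.0-fold lower number from compound 3 to compound 4 (0.30 log units; within the scatter) possibly just beyond the scatter. Compound 4 is estimated at 2000 nM, with a range from 600 nM to 6000 nM.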

Compound 4, solubility: 5000 nM
Compound 4: middle estimate off by 2.5-fold (0.40 log units), on the low side, within the range that was stated.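

In this assay, among the compounds shown here, methyl in place of hydrogen on an aromatic carbon, ortho to a large group, gives a step within the scatter (a 1.3-fold higher number from compound 3 to compound 4 (0.10 log units; within the scatter)), the first reading at this position. Hydrogen in place of chloro on an aromatic carbon gives a step beyond the scatter (an at least 5.0-fold higher number from compound 2 to compound 4 (0.69 log units; beyond the scatter)). The value of compound 2 is a limit of the assay and not a number: (the limit of < 1000 nM in this assay, at which 1 of the 4 values shown sits).

The compounds shown leave open whether an ethyl group, an amine or a carboxylic acid at this position would also stay within the scatter of hydrogen. They also leave open how far the step from chloro reaches.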